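Swapping the methylphenyl of compound 3 for a pyridyl

This account rests on a few compounds, and the source may have more. Where it says the series, first, only, none or still open, it means among the compounds named here.

Measured compounds:
- compound 1 `C[C@@H](NC(=O)c1ccc(C#Cc2ccccc2)cn1)C(C)(C)O` gives 43.2%
- compound 2 `C[C@@H](NC(=O)c1ccc(C#Cc2ccc(F)cc2)cn1)C(C)(C)O` gives 38.4%
- compound 3 `Cc1ccccc1C#Cc1ccc(C(=O)N[C@H](C)C(C)(C)O)nc1` gives 24.1%

All three share the same core and were tested in an ADME assay on HEK293 cells for agonist activity at metabotropic glutamate receptor 5 (Rattus norvegicus), read by fluorescence and calcium flux; on this read-out lower numbers stand for smaller maximal responses and higher numbers for larger maximal responses. Compound 3 stands lowest of the three numbers: its nearest neighbour is compound 2, a number 14.3 percentage points lower from compound 2 to compound 3 (beyond the scatter), and the furthest is compound 1, a number 19.1 percentage points lower from compound 1 to compound 3 (beyond the scatter). The two compounds without a methyl, compound 1 and compound 2, lie close together: a number 4.8 percentage points lower from compound 1 to compound 2 (within the scatter).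

Compound 4 `C[C@@H](NC(=O)c1ccc(C#Cc2ccncc2)cn1)C(C)(C)O` is not yet measured. It differs from compound 3 in one place: pyridin-4-yl in place of 2-methylphenyl on a triple-bonded carbon. The measured steps that bear on this are the two that remove or add the methyl on the aromatic ring, a number 19.1 percentage points lower from compound 1 to compound 3 (beyond the scatter) and a number 14.3 percentage points lower from compound 2 to compound 3 (beyond the scatter), both modest and both beyond the scatter. Among the measured compounds shown here, compound 4 carries no methyl, so a return toward the level of compound 1 and compound 2 is expected, although no measured step shows what replacing a carbon ring by a pyridin-4-yl does on its own, which widens the range. The expected step is a number 15.9 percentage points higher from compound 3 to compound 4 (beyond the scatter), upward and beyond the scatter. For compound 4 the estimate in this assay is 40%, between 26% and 54%.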

Compound 4, largest response reached (reported as efficacy), in percent of the reference or control that the assay uses: 22.4%
Estimate against measurement, compound 4: 17.6 percentage points above; the whole stated range lies above it.
By their numbers in this assay, from the lowest: compounds 4 and 3 (each within the scatter of the next); then compounds 2 and 1 (each within the scatter of the next).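

In this assay a lower maximal response does not need a methyl on the ring: pyridin-4-yl in place of phenyl gives a number 20.8 percentage points lower from compound 1 to compound 4 (beyond the scatter) and pyridin-4-yl in place of 4-fluorophenyl gives a number 16 percentage points lower from compound 2 to compound 4 (beyond the scatter) even though neither change adds one. Pyridin-4-yl in place of 2-methylphenyl on the triple-bonded carbon gives a number 1.7 percentage points lower from compound 3 to compound 4 (within the scatter) so these two quite different rings cannot be told apart on this read-out, and the earlier picture of the methyl as the one feature separating compound 3 from compound 1 and compound 2 no longer covers all four compounds. Nothing available here explains why the ring nitrogen of compound 4 or the methyl of compound 3 goes with a lower response than the plain phenyl of compound 1.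

The compounds shown leave open whether a ring nitrogen elsewhere, as in pyridin-3-yl or pyridin-2-yl, would give the same response as pyridin-4-yl. They also leave open what a methoxy group or an amine on the phenyl ring would do, and whether a methyl on a pyridine ring would lower the response any further.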